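Swapping methoxy for cyano on the pendant phenyl ring

The compounds below may be only part of what the source reports. "The series", "measured", "known", "first", "only" and "open" are said of these compounds alone.

Measured compounds:
- compound 1 `COc1ccc(-c2cc([N+](=O)[O-])cc3cc(C(O)(c4ccc(C#N)cc4)c4cncn4C)oc23)cc1`: 36 nM
- compound 2 `COC(=O)c1cc(-c2cccc(OC)c2)c2oc(C(O)(c3ccc(C#N)cc3)c3cncn3C)cc2c1`: 36.3 nM
- compound 3 `COc1cccc(-c2cc(C#N)cc3cc([C@](N)(c4ccc(C#N)cc4)c4cncn4C)oc23)c1`: 1.5 nM

In a functional assay on QG-56 cells (Homo sapiens) for antiproliferative activity (on this read-out higher numbers stand for weaker inhibition and lower numbers for stronger inhibition), compound 1 gives 36 nM, the second highest of the three numbers. Compound 2 gives 36.3 nM, which lies within the scatter of compound 1, so the two cannot be told apart. Compound 3, at 1.5 nM, stands well apart from both, beyond the scatter.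

Compound 4 `Cn1cncc1C(O)(c1ccc(C#N)cc1)c1cc2cc([N+](=O)[O-])cc(-c3ccc(C#N)cc3)c2o1` has not yet been measured. It differs from compound 1 in one place: cyano in place of methoxy on an aromatic carbon. Going by the values given here, nothing among the three measured compounds isolates this exchange, so there is no measured step to lean on; the expectation rests only on the size of the change, a two-heavy-atom group replaced by another two-heavy-atom group on a six-membered aromatic ring of carbon only.

The expected step is a 1.2-fold lower number from compound 1 to compound 4 (0.08 log units; within the scatter), most likely none beyond the scatter, in either direction. Compound 4 is therefore estimated at 30 nM in this assay. The expected range for compound 4 is estimated to run from 8 nM to 120 nM.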

Compound 4, half-maximal inhibitory concentration: 32.6 nM
Estimate against measurement, compound 4: 1.1-fold (0.04 log units) below, and the stated range covers the measured number.
By their numbers in this assay, from the lowest: compound 3; then compounds 4, 1 and 2 (each within the scatter of the next).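

In this assay, going from 4-methoxyphenyl to 4-cyanophenyl gives a 1.1-fold lower number from compound 1 to compound 4 (0.04 log units; within the scatter), so the read-out does not tell these two groups apart at this position, para to a large group. Going by these compounds alone, the earlier compounds all differed from one another in more than one place, so none could show what a single exchange on this ring does; this pair is the first to isolate one, and here the cyano group serves in place of methoxy with no change that can be read. Nothing measured here explains why the two groups give matching numbers.

On these data alone, it remains open whether a larger or charged group on this carbon, such as an amine or a carboxylic acid, would also stay within the scatter. As far as these compounds go, it is also open whether the same exchange would behave alike with the other substituents on the shared core.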